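A Larger Amide Headgroup Replaces a Small One

The source may hold more compounds than are shown below. What is called first, only, known or untested is meant among the compounds shown, and "the series" means these compounds.

Two compounds have been run in an ADME assay on cells (Hepatocyte, Rattus norvegicus) for metabolic stability; a higher number here means faster removal of the compound, a lower number slower removal. Compound 1 `Cc1ccc2[nH]c(C(=O)N[C@H]3CN(S(=O)(=O)C4CCOCC4)C[C@@H]3C(=O)NCCN(C)C)cc2c1` gives 4 uL/min. Compound 2 `O=C(N[C@H]1CN(S(=O)(=O)c2ccccc2)C[C@@H]1C(=O)N[C@H]1CCCNC1)c1cn(C2CC2)cn1` returns only a limit of the assay, < 1 uL/min, so for it no true number is known. That is where the limit of < 1 uL/min in this assay, at which 1 of the 2 values shown sits, stands, and compound 2 is one of the two compounds measured.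

Compound 3 `O=C(N[C@H]1CN(S(=O)(=O)c2ccccc2)C[C@@H]1C(=O)N[C@H]1CCCNC1)c1cc(-c2ccccc2Cl)on1` has not yet been measured in this assay. It differs from compound 2 in one place: a group of 12 heavy atoms (9 carbon, 1 nitrogen, 1 oxygen, 1 chlorine; one five-membered aromatic ring with 2 hetero atoms, one six-membered aromatic ring of carbon only) in place of a group of 8 heavy atoms (6 carbon, 2 nitrogen; one three-membered non-aromatic ring of carbon only, one five-membered aromatic ring with 2 hetero atoms), on a carbonyl carbon. Among the compounds with values here, no measured pair here is separated by a single change, so nothing measured tells how an exchange of this kind moves the read-out. The expectation that follows rests only on where compound 2 stands.

With compound 2 already at the limit of what the assay reports, the step from compound 2 to compound 3 is expected to point toward faster removal, at a size of an at least 4.0-fold higher number from compound 2 to compound 3 (0.60 log units; beyond the scatter), though it may not exceed the usual scatter. Compound 3 is therefore expected to give about 4 uL/min, with a likely range from 1 uL/min to 15 uL/min, and a fair chance that it, too, is reported only as a limit.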

Compound 3, intrinsic clearance in a liver preparation (reported as CLH), per the amount of preparation that the assay uses: 8.3 uL/min
Compound 3: middle estimate off by 2.1-fold (0.32 log units), on the low side; measured number inside the range.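

Within the data shown here, the exchange of 1-cyclopropyl-1H-imidazol-4-yl for the larger group on the carbonyl carbon provides the first single-change comparison in this assay, and it gives an at least 8.3-fold higher number from compound 2 to compound 3 (0.91 log units; beyond the scatter). This shows that the group at this place can move the rate of removal beyond the usual scatter while the rest of the molecule stays the same, even though the two groups have the same counts of hydrogen-bond donors and acceptors and neither carries a net charge. The step gives only a minimum size, because compound 2 is reported only as a limit: the limit of < 1 uL/min in this assay, at which 1 of the 3 values shown sits.

The entering group differs from the one it replaces in several ways at once, so the compounds shown leave open whether the rise follows from the chlorine, the six-membered aromatic ring or the five-membered aromatic ring with 2 hetero atoms. A group with fluorine in place of the chlorine, or a simple methyl on the five-membered ring in place of the whole chlorine-bearing ring, would help separate these parts, and compound 1 differs in too many places to settle the question.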